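Aromatic methyl and chain change in an antiproliferative series

A few compounds are considered here, and "the series" means these few. Any claim that something is new, unique, unknown or untested is made for them only; others in the source may bear on it.

In a functional assay on MCF7 cells (Homo sapiens) for antiproliferative activity, read by MTT assay (a higher number here means a weaker inhibitor, a lower number a stronger inhibitor), compound 1 `CC/C=C\C/C=C\C/C=C\CCCCCCCc1cc(=O)c2c(O)cc(OCOC)c(C)c2o1` gives 17500 nM. Compound 2 `CC/C=C\C/C=C\C/C=C\CCCCCCCc1cc(=O)c2c(O)c(C)c(OCOC)c(C)c2o1` differs from compound 1 by methyl in place of hydrogen on an aromatic carbon. For compound 2 the result in this assay is a limit of the assay, > 84100 nM. The step is an at least 4.8-fold higher number from compound 1 to compound 2 (0.68 log units; beyond the scatter), with compound 2 sitting at the limit of > 84100 nM in this assay, at which 1 of the 3 values shown sits. Compound 3 `CCCCCCCCCCCCCCCc1cc(=O)c2c(O)cc(OCOC)c(C)c2o1` differs from compound 1 by a group of 8 heavy atoms (8 carbon; no ring) in place of a group of 10 heavy atoms (10 carbon; no ring), on a saturated chain carbon, seven bonds along the chain from an aromatic carbon. For compound 3 the result in this assay is likewise a limit, > 67200 nM. The step is an at least 3.8-fold higher number from compound 1 to compound 3 (0.58 log units; beyond the scatter), with compound 3 sitting at the limit of > 67200 nM in this assay, at which 1 of the 3 values shown sits. Compound 4 `CCCCCCCCCCCCCCCc1cc(=O)c2c(O)c(C)c(OCOC)c(C)c2o1`, not yet measured, differs from compound 3 by methyl in place of hydrogen on an aromatic carbon, the same change as from compound 1 to compound 2, at a place described in the same words. Compound 3 already stands at a limit, so for compound 4 a limit is expected as well. The expected step is a step that the limit leaves unreadable from compound 3 to compound 4, resting on an at least 4.8-fold higher number from compound 1 to compound 2 (0.68 log units; beyond the scatter). For compound 4 the estimate in this assay is 250000 nM, between 70000 nM and 1000000 nM.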

Compound 4, half-maximal inhibitory concentration: > 67200 nM
Compound 4: no number, only a limit; the forecaster's own chance of this, stated with the estimate: 90%; the middle value does not contradict the limit.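

Compound 2, compound 3 and compound 4 all stand at limits of the assay, so the steps from compound 3 to compound 4 and from compound 2 to compound 4 cannot be read. Open: whether methyl in place of hydrogen on an aromatic carbon has the same size of effect with both chains.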